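Removing one hydroxy from the dihydroxyphenyl of compound 3

This account rests on a few compounds, and the source may have more. Where it says the series, first, only, none or still open, it means among the compounds named here.

Three compounds of this series carry a shared core with a varied aryl group on the carbon double-bonded to nitrogen, and are measured in a functional assay on U-87MG ATCC cells (Homo sapiens) for cytotoxicity, read by MTT assay, with a stated time of 72 h; on this read-out higher numbers stand for weaker inhibition and lower numbers for stronger inhibition. Compound 1 `COc1ccc(OC)c(/C=N/NC(=O)Nc2ccc(Oc3ccnc(-c4nncn4CCN(C)C)c3)c(F)c2)c1` gives 6400 nM. Compound 2 `CN(C)CCn1cnnc1-c1cc(Oc2ccc(NC(=O)N/N=C/c3ccccc3O[N+](=O)[O-])cc2F)ccn1` gives 7150 nM. Compound 3 `CN(C)CCn1cnnc1-c1cc(Oc2ccc(NC(=O)N/N=C/c3ccc(O)c(O)c3)cc2F)ccn1` gives only a limit, > 100000 nM, which is the assay limit rather than a number (the limit of > 100000 nM in this assay, at which 1 of the 3 values shown sits). Among the measured compounds shown here, the step of a 1.1-fold higher number from compound 1 to compound 2 (0.05 log units; within the scatter) is within the scatter, while an at least 15-fold higher number from compound 1 to compound 3 (1.19 log units; beyond the scatter) and an at least 13-fold higher number from compound 2 to compound 3 (1.14 log units; beyond the scatter) are both large, so compound 3 stands as the sole compound at the limit.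

Compound 4 `CN(C)CCn1cnnc1-c1cc(Oc2ccc(NC(=O)N/N=C/c3ccc(O)cc3)cc2F)ccn1` differs from compound 3 by hydrogen in place of hydroxy on an aromatic carbon. For the measured compounds named here, no measured step removes a single hydroxy from this aryl group; the two steps that bear on it, an at least 15-fold higher number from compound 1 to compound 3 (1.19 log units; beyond the scatter) and an at least 13-fold higher number from compound 2 to compound 3 (1.14 log units; beyond the scatter), show only that the dihydroxyphenyl sits far weaker than the dimethoxyphenyl or the nitrooxyphenyl. A partial return toward those two is expected for compound 4, so the estimated step is an at least 2.5-fold lower number from compound 3 to compound 4 (0.39 log units; beyond the scatter), with the compound still well short of compound 1. For compound 4 the expected value in this assay is 40000 nM, with a range from 8000 nM to 150000 nM.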

Compound 4, half-maximal inhibitory concentration: 7750 nM
The estimate for compound 4 lay 5.2-fold (0.71 log units) above the measured number, outside the stated range (below it).
By their numbers in this assay, from the lowest: compounds 1, 2 and 4 (each within the scatter of the next). At a limit, above all of these: compound 3.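

In this assay, among the compounds shown here, the change from 3,4-dihydroxyphenyl to 4-hydroxyphenyl is the first one-place change at this aryl group that moves the read-out beyond the scatter, and the step is an at least 12-fold lower number from compound 3 to compound 4 (1.11 log units; beyond the scatter) with the loss tied to that single hydroxy. Compound 4 keeps one hydroxy and still sits with the other two aryl groups, as a 1.1-fold higher number from compound 2 to compound 4 (0.03 log units; within the scatter) and a 1.2-fold higher number from compound 1 to compound 4 (0.08 log units; within the scatter) show, so a single hydroxy on the ring is tolerated among these compounds and only the dihydroxyphenyl of compound 3 falls away. The value of compound 3 is a limit of the assay and not a number: the limit of > 100000 nM in this assay, at which 1 of the 4 values shown sits.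

On these data alone, it stays open whether the loss belongs to the hydroxy on its own or to the pair, which a 3-hydroxyphenyl would separate. As far as these compounds go, whether an amine or a carboxylic acid in place of that hydroxy would hold the level of compound 4 also remains unknown.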